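A few compounds are considered here, and "the series" means these few. Any claim that something is new, unique, unknown or untested is made for them only; others in the source may bear on it.

Within the data shown here, compound 1 `CN(C)c1ccc(-c2cccc([N+](=O)[O-])c2)cc1` has the lower of the two numbers measured so far: in an assay on COS-7 cells for inhibition of patatin-like phospholipase domain-containing protein 2 (Mus musculus), tested at 200 uM (on this read-out lower numbers stand for less inhibition and higher numbers for more inhibition at the one concentration tested (going by the name of the read-out)), compound 1 gives 21%. Compound 2 `CC(C)OC(=O)Nc1cccc(-c2ccc(N(C)C)cc2)c1` stands highest of the two numbers; in this assay compound 2 gives 69%. Among the measured compounds shown here, the one step between them, a number 48 percentage points higher from compound 1 to compound 2 (beyond the scatter), comes from putting (isopropoxycarbonyl)amino in place of nitro on an aromatic carbon.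

Compound 3 `CN(C)c1ccc(-c2cccc(NC(=O)C(C)(C)C)c2)cc1` keeps the shared core of compound 2 and differs from it in one place: tert-butyl in place of isopropoxy on a carbonyl carbon. For the measured compounds named here, no measured step bears directly on this change, since the only step known, a number 48 percentage points higher from compound 1 to compound 2 (beyond the scatter), replaced the whole nitro group with the carbamate and did not vary what sits on the carbonyl carbon. The amide-type nitrogen and the carbonyl are retained in compound 3. Going by the values given here, with no step of the same kind to lean on, the account expects a step for compound 3 that is small, a number 9 percentage points lower from compound 2 to compound 3 (within the scatter), not beyond the scatter in this assay. Compound 3 is therefore estimated at 60%, within the range 35% to 85%.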

Compound 3, a percentage reported as inhibition, at one concentration (the size of the read-out at that concentration, not a potency): 25%
The estimate for compound 3 lay 35 percentage points above the measured number; the measured number lies below the stated range.
By their numbers in this assay, from the lowest: compounds 1 and 3 (each within the scatter of the next); then compound 2.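

In this assay, among these compounds, the earlier compounds showed only that the carbamate group outdid nitro, and the present result moves attention one atom further out, to what sits on the carbonyl carbon: tert-butyl in place of isopropoxy gives a number 44 percentage points lower from compound 2 to compound 3 (beyond the scatter) in a change that keeps the amide-type nitrogen and the carbonyl, so these two alone do not carry the high number of compound 2. Set against nitro, the new group gives a number 4 percentage points higher from compound 1 to compound 3 (within the scatter) and so does not separate from it in this read-out, which leaves the gain seen with (isopropoxycarbonyl)amino tied, among these compounds, to the isopropoxy group on the carbonyl carbon. No measurement at hand accounts for why this exchange has so large an effect.

From the compounds shown here alone, what remains open is whether the oxygen on the carbonyl carbon is what counts or the isopropoxy group as a whole, as only these two groups stand at this place. An ethoxy, a tert-butoxy or a methylamino group on the same carbonyl carbon would tell these readings apart.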